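Extending the Chain of Compound 2 With Butyl

This account rests on a few compounds, and the source may have more. Where it says the series, first, only, none or still open, it means among the compounds named here.

Values measured so far in a functional assay, with a stated time of 30 min (a higher number here means a weaker inhibitor, a lower number a stronger inhibitor), are these
- Compound 1 `CCCCCCCCOc1cc(OC)c(Br)cc1C(C)=O` gives 39000000 nM
- Compound 2 `CCCCOc1cc(OC)ccc1C(C)=O` gives 43300000 nM

Compound 2 and compound 1 lie within the usual scatter of each other, so neither stands apart on these numbers. The two differ in more than one place, so no single change can be read from this pair.

Compound 3 `CCCCCCCCOc1cc(OC)ccc1C(C)=O` differs from compound 2 in one place: butyl in place of hydrogen on a saturated chain carbon, four bonds along the chain from an oxygen on an aromatic ring on a saturated chain carbon, four bonds along the chain from an oxygen on an aromatic ring. Among the compounds with values here, no measured pair shows this change on its own. Compound 3 shares its chain with compound 1, which gives 39000000 nM and so lies within the scatter of compound 2, although compound 1 also carries a bromine that compound 3 lacks. On that evidence, the change expected in this assay is none beyond the scatter, with at most a slight drift towards a lower number. The estimated step of a 1.2-fold lower number from compound 2 to compound 3 (0.09 log units; within the scatter) is therefore small. For compound 3 the estimated value is 35000000 nM with an expected range from 12000000 nM to 90000000 nM when it is measured.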

Compound 3, half-maximal inhibitory concentration: 40000000 nM
For compound 3 the middle estimate is 1.1-fold (0.06 log units) below the measured one, and the stated range covers the measured number.
By their numbers in this assay, from the lowest: compounds 1, 3 and 2 (each within the scatter of the next).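

Compound 3 splits the two-place difference between compound 1 and compound 2 into two single changes, which the earlier pair could not do. In this assay butyl in place of hydrogen on a saturated chain carbon, four bonds along the chain from an oxygen on an aromatic ring, gives a step within the scatter (a 1.1-fold lower number from compound 2 to compound 3 (0.03 log units; within the scatter)), and hydrogen in place of bromo on an aromatic carbon also gives a step within the scatter (a 1.0-fold higher number from compound 1 to compound 3 (0.01 log units; within the scatter)), so neither change alone separates these compounds, and the closeness of compound 1 and compound 2 does not come from two large steps in opposite directions. Nothing measured on these compounds accounts for this result.

Bromo is seen here only alongside the octyl chain that compound 1 and compound 3 share, so its step alongside the butyl chain of compound 2 remains open. Also open, as far as these compounds go, is whether a much longer chain, or a chain carrying an amine or a carboxylic acid, would move the number in this assay beyond the scatter.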